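The source may report more compounds than this note shows. Statements on the series, on what has been measured and on what is new or still open speak of the compounds shown alone.

Measured so far:
compound 1 `O=C(NCc1ccc(S(=O)(=O)c2cncc(C(F)(F)F)c2)cc1)N1Cc2ccncc2C1` — 83000 nM in a physicochemical assay for solubility, in phosphate buffer, with a stated time of 24 h, at pH 7.4, tested at 100 uM; a lower number here means a less soluble compound, a higher number a more soluble compound
compound 2 `O=C(NCc1ccc(S(=O)(=O)C2CCOCC2)cc1)N1Cc2ccncc2C1` — 206000 nM in this assay

Compound 1 stands lowest of these two numbers in this assay; its nearest neighbour is compound 2, with a 2.5-fold higher number from compound 1 to compound 2 (0.39 log units; beyond the scatter). That step is beyond the scatter but modest.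

Compound 3 `CC(=O)N1CCC(S(=O)(=O)c2ccc(CNC(=O)N3Cc4ccncc4C3)cc2)CC1` is not yet measured in this assay. It differs from compound 1 in one place: 1-acetylpiperidin-4-yl in place of 5-(trifluoromethyl)pyridin-3-yl on a sulfonyl sulfur. Among the measured compounds shown here, the only measured step that bears on this change is a 2.5-fold higher number from compound 1 to compound 2 (0.39 log units; beyond the scatter), where a six-membered non-aromatic ring with one hetero atom likewise took the place of 5-(trifluoromethyl)pyridin-3-yl on the sulfonyl sulfur. On that basis an upward step of about the same size is expected for compound 3, a 2.5-fold higher number from compound 1 to compound 3 (0.40 log units; beyond the scatter). For the measured compounds named here, the estimate for compound 3 in this assay is 210000 nM, with a range from 110000 nM to 400000 nM; with only one comparable step at hand, the range is kept wide.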

Compound 3, solubility: 187000 nM
The estimate for compound 3 lay 1.1-fold (0.05 log units) above the measured number; low and high end bracket the measured number.
By their numbers in this assay, from the lowest: compound 1; then compounds 3 and 2 (each within the scatter of the next).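

In this assay, a second six-membered non-aromatic ring with one hetero atom in place of 5-(trifluoromethyl)pyridin-3-yl on the sulfonyl sulfur also gives a modest upward step beyond the scatter (a 2.3-fold higher number from compound 1 to compound 3 (0.35 log units; beyond the scatter)), so this change now holds for two groups rather than for oxan-4-yl alone. The two non-aromatic groups are not separated in this read-out: 1-acetylpiperidin-4-yl in place of oxan-4-yl stays within the scatter (a 1.1-fold lower number from compound 2 to compound 3 (0.04 log units; within the scatter)), even with the double bond outside aromatic rings that the acetylated group brings. No measured evidence accounts for either step.

As far as these compounds go, whether a free amine or a carboxylic acid on the non-aromatic ring would move the number beyond the scatter remains open. Also open, from the compounds shown here alone, is where a pyridin-3-yl group without the trifluoromethyl would stand in this assay.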